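The source may hold more compounds than are shown below. What is called first, only, known or untested is meant among the compounds shown, and "the series" means these compounds.

Compound 3 `COc1ccc(C2N=C(SCc3ccccc3)NC(C)=C2C(=O)Nc2ccc(Br)cc2)cc1` gives 5.6% in a functional assay on the whole organism (artery, strain albino) with Rattus norvegicus as the target, with a stated time of 900 min, at a dose of 10 mg/kg by the oral route; a lower number here means less inhibition, a higher number more inhibition at the dose given (going by the name of the read-out). Compound 1 `CC1=C(C(=O)Nc2ccc(Br)cc2)C(c2ccc(Cl)cc2Cl)N=C(SCc2ccccc2)N1` gives 8.2% in this assay, and the difference between the two is a number 2.6 percentage points lower from compound 1 to compound 3 (within the scatter). Compound 2 `CC1=C(C(=O)Nc2ccc(Br)cc2)C(c2ccc(Cl)cc2Cl)N=C(SCc2ccccc2Cl)N1` gives 16.4% in this assay, a gap from compound 3 that lies beyond the scatter. Compound 4 `COc1ccc(C2N=C(SCc3ccccc3Cl)NC(C)=C2C(=O)Nc2ccc(Br)cc2)cc1` differs from compound 3 by chloro in place of hydrogen on an aromatic carbon. The same change has been measured once already on this series: a number 8.2 percentage points higher from compound 1 to compound 2 (within the scatter). On that single precedent, a step of similar size is expected, a number 7.4 percentage points higher from compound 3 to compound 4 (within the scatter), which would stay within the scatter rather than mark a clear shift. Compound 4 is therefore estimated at 13% in this assay, with a range from 2% to 25%.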

Compound 4, a percentage reported as inhibition, in the whole organism at one dose (the size of the read-out at that dose, not a potency): 7.2%
Compound 4: the middle estimate sits 5.8 percentage points above what was measured; the range from low to high includes it.
By their numbers in this assay, from the lowest: compounds 3, 4, 1 and 2 (each within the scatter of the next, the first and the last beyond it).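

With the 4-methoxyphenyl group on the saturated ring carbon, 2-chlorobenzyl in place of benzyl gives a number 1.6 percentage points higher from compound 3 to compound 4 (within the scatter) in this assay. The chloro step has now been read on two cores, and neither reading leaves the scatter: the same change on two cores in this assay, a number 8.2 percentage points higher (within the scatter) from compound 1 to compound 2 and a number 1.6 percentage points higher (within the scatter) from compound 3 to compound 4, 6.6 percentage points apart, within the scatter of two such steps. With the chloro present, the other change gives a number 9.2 percentage points lower from compound 2 to compound 4 (within the scatter) and again reads alike on both cores: the same change on two cores in this assay, a number 2.6 percentage points lower (within the scatter) from compound 1 to compound 3 and a number 9.2 percentage points lower (within the scatter) from compound 2 to compound 4, 6.6 percentage points apart, within the scatter of two such steps. The compounds shown leave open whether an amine or a carboxylic acid in place of the chloro would give a step beyond the scatter. They also leave open what a longer chain in place of benzyl would do.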